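Swapping Diformylphenyl for Difluorophenyl on a Shared Core

The compounds below may be only part of what the source reports. "The series", "measured", "known", "first", "only" and "open" are said of these compounds alone.

Of the compounds shown here, three have so far been tested in a functional assay on NCI-H460 cells (Homo sapiens) for inhibition, read by MTT assay, with a stated time of 72 h; a lower number here means a stronger inhibitor, a higher number a weaker inhibitor. Compound 1 `Cc1ccc2c(c1)/C(=c1/sc(=Cc3ccc(C=O)c(C=O)c3)c(=O)n1CCN(C)C)C(=O)N2` gives 4030 nM. Compound 2 `CCN(CC)CCCn1c(=O)c(=Cc2ccc(F)c(F)c2)s/c1=C1\C(=O)Nc2ccc(F)cc21` gives 1300 nM, and compound 3 `CN(C)CCN1C(=O)/C(=C/c2ccc(O)cc2)SC1=S`, built on a different core, gives 46100 nM. Among these three numbers compound 1 stands second highest: its nearest neighbour is compound 2, whose number is lower by a margin beyond the scatter, and its furthest is compound 3, whose number is higher by a much wider margin.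

Compound 4 `Cc1ccc2c(c1)/C(=c1/sc(=Cc3ccc(F)c(F)c3)c(=O)n1CCN(C)C)C(=O)N2` has not yet been measured. It differs from compound 1 in one place: 3,4-difluorophenyl in place of 3,4-diformylphenyl on a double-bonded chain carbon bound to an aromatic carbon. Among the compounds with values here, no measured pair shows this exact change, so its size cannot be read off directly. Compound 2 carries the same 3,4-difluorophenyl group, although on a core that differs elsewhere, and its value in this assay sits below that of compound 1. On that basis the step of a 2.5-fold lower number from compound 1 to compound 4 (0.40 log units; beyond the scatter) is expected to be modest but probably beyond the scatter, in the direction of a lower number. The estimate for compound 4 is 1600 nM, with a range from 500 nM to 5000 nM.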

Compound 4, half-maximal inhibitory concentration: 59700 nM
Beside the measured number, compound 4's estimate is 37-fold (1.57 log units) below it, and the stated range ends below it.
By their numbers in this assay, from the lowest: compound 2; then compound 1; then compounds 3 and 4 (each within the scatter of the next).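

Within the data shown here, this is the first direct reading of a single change at this position: in this assay, replacing 3,4-diformylphenyl with 3,4-difluorophenyl on a double-bonded chain carbon bound to an aromatic carbon gives a 15-fold higher number from compound 1 to compound 4 (1.17 log units; beyond the scatter), a large step with everything else on the shared core held fixed. The position is therefore far from indifferent to what it carries, and on this core the compound with 3,4-diformylphenyl is clearly the stronger inhibitor of the pair. The swap replaces a group with 2 hydrogen-bond acceptors by one with 0 and exchanges oxygen-bearing carbonyl groups for fluorine, but nothing measured here indicates which of these differences, if any, accounts for the step.

On these data alone, it remains open whether a phenyl ring carrying a single formyl group, or two nitrile or two carboxylic acid groups in place of the formyl groups, would give a number nearer that of compound 1 or that of compound 4. As far as these compounds go, it is also open whether a step of this size would appear on a different core, since this single pair shows the change on only one.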